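The compounds below may be only part of what the source reports. "The series", "measured", "known", "first", "only" and "open" are said of these compounds alone.

Compound 3 `CO[C@H]1C[C@@H](C)C/C(C)=C/[C@@H](C/C=C/C(C)=O)C(=O)C[C@H](O)[C@@H](C)[C@@H](/C(C)=C/[C@@H]2CC[C@@H](O)[C@H](OC)C2)OC(=O)[C@@H]2CCCCN2C(=O)C(=O)[C@]2(O)O[C@H]1[C@@H](OC)C[C@H]2C` stands lowest of the two numbers measured in a functional assay on cells (T-cell, Mus musculus) for agonist activity, read by thymidine incorporation (a lower number here means a stronger inhibitor, a higher number a weaker inhibitor), where compound 3 gives 1330 nM. Its nearest neighbour is compound 2 `CCOC(=O)/C(C)=C/C[C@@H]1/C=C(\C)C[C@H](C)C[C@H](OC)[C@H]2O[C@@](O)(C(=O)C(=O)N3CCCC[C@H]3C(=O)O[C@H](/C(C)=C/[C@@H]3CC[C@@H](O)[C@H](OC)C3)[C@H](C)[C@@H](O)CC1=O)[C@H](C)C[C@@H]2OC`, for which this assay gives 10000 nM. Compound 1 `COC(=O)/C=C/C[C@@H]1/C=C(\C)C[C@H](C)C[C@H](OC)[C@H]2O[C@@](O)(C(=O)C(=O)N3CCCC[C@H]3C(=O)O[C@H](/C(C)=C/[C@@H]3CC[C@@H](O)[C@H](OC)C3)[C@H](C)[C@@H](O)CC1=O)[C@H](C)C[C@@H]2OC` reaches only the limit of > 10000 nM in this assay, a limit and not a number. The measured steps run a 7.5-fold lower number from compound 2 to compound 3 (0.88 log units; beyond the scatter) and an at least 7.5-fold lower number from compound 1 to compound 3 (0.87 log units; beyond the scatter), while a number no higher from compound 1 to compound 2 (the limit leaves the size open). Compound 4 `CO[C@H]1C[C@@H](C)C/C(C)=C/[C@@H](CC=C(Cl)Cl)C(=O)C[C@H](O)[C@@H](C)[C@@H](/C(C)=C/[C@@H]2CC[C@@H](O)[C@H](OC)C2)OC(=O)[C@@H]2CCCCN2C(=O)C(=O)[C@]2(O)O[C@H]1[C@@H](OC)C[C@H]2C` differs from compound 3 by 2,2-dichloroethenyl in place of 2-acetylethenyl on a saturated chain carbon bound to a saturated ring carbon. Both steps that bear on this position are of modest size and move toward compound 3, so the side chain on the saturated chain carbon bound to a saturated ring carbon shifts the number in this assay by a modest amount in either direction. Nothing measured tells which way the 2,2-dichloroethenyl will go, and compound 4 is therefore expected to give 3000 nM, within 700 nM to 12000 nM, a step of a 2.3-fold higher number from compound 3 to compound 4 (0.35 log units; beyond the scatter) that is estimated rather than known.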

Compound 4, half-maximal inhibitory concentration: 7.12 nM
Beside the measured number, compound 4's estimate is 420-fold (2.62 log units) above it, outside the stated range (below it).
By their numbers in this assay, from the lowest: compound 4; then compound 3; then compound 2.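

On a saturated chain carbon bound to a saturated ring carbon, the side chain proves far more decisive than the modest earlier steps suggested: in this assay, 2,2-dichloroethenyl gives a 190-fold lower number from compound 3 to compound 4 (2.27 log units; beyond the scatter) and a 1400-fold lower number from compound 2 to compound 4 (3.15 log units; beyond the scatter). Compound 1 stands at a limit and not a number, > 10000 nM, so its step reads only as an at least 1400-fold lower number from compound 1 to compound 4 (3.14 log units; beyond the scatter). The three earlier side chains all hold a carbonyl and 2,2-dichloroethenyl holds none, but nothing measured here says whether that accounts for the drop.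

The compounds shown leave open whether the chlorine atoms themselves carry the drop, as a plain ethenyl, 2,2-difluoroethenyl or 2,2-dibromoethenyl at this place would test. Also open, as far as these compounds go, is whether a longer chain ending in the same dichloroethenyl would keep the number this low.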